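Swapping the propenyl-linked oxopiperazine for a piperazine amide

The source may hold more compounds than are shown below. What is called first, only, known or untested is meant among the compounds shown, and "the series" means these compounds.

Compound 1 `CCc1nn2c(C)cc(C)nc2c1Cc1ccc(/C=C/CN2CCNC(=O)C2)cc1` carries the lowest number of the two measured here. In a functional assay on HeLa cells for antagonist activity at G-prodeshotein coupled receptor 4 (Homo sapiens), read by HTRF and cAMP accumulation, with a stated time of 15 min (a higher number here means a weaker inhibitor, a lower number a stronger inhibitor), compound 1 gives 27 nM. Compound 2 `CCc1nc2c(C)cc(C)nn2c1Cc1ccc(/C=C/CN2CCN(C(C)C)CC2)cc1` differs from compound 1 both in the arrangement of its core and in the chain on the phenyl ring. In this assay compound 2 gives 74 nM; the two values lie apart beyond the scatter, with compound 1 the stronger inhibitor, but no single change separates them, so only the two numbers themselves can be read.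

Compound 3 `CCc1nn2c(C)cc(C)nc2c1Cc1ccc(CCC(=O)N2CCNCC2)cc1` is not yet measured. It follows from compound 1 by one change on the phenyl ring, on the aromatic carbon para to a large group: 2-((piperazin-1-yl)carbonyl)ethyl in place of 3-(3-oxopiperazin-1-yl)prop-1-en-1-yl on an aromatic carbon. The count of heavy atoms, ring, donors and acceptors is unchanged; one double bond outside aromatic rings is lost, and the carbonyl moves from inside the ring to the chain.

With no measured step of this kind in the series, the expectation for this assay rests on compound 1 alone. A modest weakening is expected, a 2.2-fold higher number from compound 1 to compound 3 (0.35 log units; beyond the scatter), of a size at or just beyond the scatter, though a value within it would not surprise. Compound 3 is thus estimated at 60 nM, with a range of 20 nM to 200 nM.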

Compound 3, half-maximal inhibitory concentration: 53 nM
Compound 3: middle estimate off by 1.1-fold (0.05 log units), on the high side; the range from low to high includes it.
By their numbers in this assay, from the lowest: compounds 1, 3 and 2 (each within the scatter of the next, the first and the last beyond it).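

In this assay, among the compounds shown here, the first step that can be read at a single place puts 2-((piperazin-1-yl)carbonyl)ethyl in place of 3-(3-oxopiperazin-1-yl)prop-1-en-1-yl on the aromatic carbon para to a large group, and it gives a 2.0-fold higher number from compound 1 to compound 3 (0.29 log units; within the scatter) on the shared core, so the two groups cannot be told apart in this read-out. The exchange is not a small one in structure: a double bond outside aromatic rings is lost and the carbonyl passes from inside the ring to the chain, yet the number stays within the scatter, so this place accepts both arrangements at the level of these two compounds. Nothing measured here explains why the two groups read alike.

Because both alterations arrive together, the contribution of the chain double bond cannot be separated from that of the carbonyl's location, and a saturated 3-(3-oxopiperazin-1-yl)propyl chain would pull them apart. Also open, going by these compounds, is how far this place stretches beyond these neutral amide groups, for instance to a carboxylic acid, a morpholine amide or a longer chain.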